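The source may hold more compounds than are shown below. What is called first, only, known or untested is meant among the compounds shown, and "the series" means these compounds.

Compound 3 `Cc1ccc(C(=O)O)cc1OCCCCOc1ccc(C(=O)CC2CCCC2)c(O)c1C` and compound 1 `Cc1c(OCCCCOc2cccc(C(=O)O)c2)ccc(C(=O)CC2CCCC2)c1O` differ by hydrogen in place of methyl on an aromatic carbon. In an assay on HEK293 cells for positive allosteric modulation of metabotropic glutamate receptor 2 (Rattus norvegicus), read by thallium flux, with a stated time of 2.5 min (a lower number here means that less compound is needed, a higher number that more compound is needed for the effect), compound 3 gives 1290 nM and compound 1 gives 451 nM, a step of a 2.9-fold lower number from compound 3 to compound 1 (0.46 log units; beyond the scatter). Compound 2 `Cc1ccc(C(=O)O)cc1OCCCCOc1ccc(C(=O)CC(C)C)c(O)c1C`, which gives 454 nM in this assay, carries the same change toward compound 4 `Cc1c(OCCCCOc2cccc(C(=O)O)c2)ccc(C(=O)CC(C)C)c1O`, not yet measured: hydrogen in place of methyl on an aromatic carbon. The two cores differ by isopropyl in place of cyclopentyl on a saturated chain carbon bound to a carbonyl carbon, with a 2.8-fold higher number from compound 2 to compound 3 (0.45 log units; beyond the scatter) in this assay. The place of the change is described in the same words for both pairs, so the change is taken as the same. For compound 4 a step of about a 2.8-fold lower number from compound 2 to compound 4 (0.45 log units; beyond the scatter) is expected, resting on the earlier step of a 2.9-fold lower number from compound 3 to compound 1 (0.46 log units; beyond the scatter). Going by the values given here, only one prior instance of this change is available, so the expected range is kept wide. Compound 4 is estimated at 160 nM in this assay, from 70 nM to 380 nM.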

Compound 4, half-maximal effective concentration: 222 nM
For compound 4 the middle estimate is 1.4-fold (0.14 log units) below the measured one; the range from low to high includes it.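

In this assay, hydrogen in place of methyl on the aromatic carbon, 5-carboxy-2-methylphenyl to 3-carboxyphenyl, again gives a lower number, a 2.0-fold lower number from compound 2 to compound 4 (0.31 log units; beyond the scatter), and its size agrees with the earlier step: the same change on two cores in this assay, a 2.9-fold lower number (0.46 log units; beyond the scatter) from compound 3 to compound 1 and a 2.0-fold lower number (0.31 log units; beyond the scatter) from compound 2 to compound 4, 1.4-fold (0.15 log units) apart, within the scatter of two such steps

Isopropyl in place of cyclopentyl also carries over, with a 2.0-fold lower number from compound 1 to compound 4 (0.31 log units; beyond the scatter), and it agrees with the earlier step on the other core: the same change on two cores in this assay, a 2.8-fold higher number (0.45 log units; beyond the scatter) from compound 2 to compound 3 and a 2.0-fold higher number (0.31 log units; beyond the scatter) from compound 4 to compound 1, 1.4-fold (0.15 log units) apart, within the scatter of two such steps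

Across these four compounds, each change keeps its direction and size on both cores, but each rests on only two steps, and this does not show that either would carry to a core outside this set.

Going by these compounds, it remains open whether chloro or methoxy in place of that methyl would follow the same course. Also open, on these data alone, is how cyclohexyl in place of cyclopentyl, or an amide in place of the carboxylic acid, would behave.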